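This account rests on a few compounds, and the source may have more. Where it says the series, first, only, none or still open, it means among the compounds named here.

Three analogues sharing one core have been tested in a functional assay on K562 cells (Homo sapiens) for cytotoxicity, read by sulforhodamine B assay, with a stated time of 48 h, tested at 100 uM; on this read-out higher numbers stand for a weaker effect at the one concentration tested and lower numbers for a stronger effect. Compound 1 `COc1cc(-c2cc(/C=C/C(=O)c3ccc(N)cc3)[nH]n2)cc(OC)c1OC` gives -3%, compound 2 `COc1ccc(-c2cc(/C=C/C(=O)c3ccc(OC)c(OC)c3)[nH]n2)cc1` gives -26%, and compound 3 `COc1cc(-c2cc(/C=C/C(=O)c3ccc(Cl)c(Cl)c3)[nH]n2)cc(OC)c1OC` gives -7%. Compound 3 thus holds the second highest of the three numbers: compound 1 lies nearest, within the scatter, while compound 2 lies furthest, beyond it. Going by the values given here, the only step measured at the same place, a number 4 percentage points lower from compound 1 to compound 3 (within the scatter), stayed within the scatter. Compound 4 `COc1ccc(C(=O)/C=C/c2cc(-c3cc(OC)c(OC)c(OC)c3)n[nH]2)cc1` differs from compound 3 by 4-methoxyphenyl in place of 3,4-dichlorophenyl on a carbonyl carbon. Among the compounds with values here, that single step bears on the change and was small; compound 2 differs from compound 3 in more than one place and offers no step of its own. The step of a number 3 percentage points lower from compound 3 to compound 4 (within the scatter) is therefore expected to stay within the scatter. Compound 4 is expected to give -10%, within -30% to 10%.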

Compound 4, a percentage reported as activity, at one concentration (the size of the read-out at that concentration, not a potency): 1%
Compound 4: the middle estimate sits 11 percentage points below what was measured; low and high end bracket the measured number.
By their numbers in this assay, from the lowest: compound 2; then compounds 3, 1 and 4 (each within the scatter of the next).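

On a carbonyl carbon, 4-methoxyphenyl in place of 3,4-dichlorophenyl gives a number 8 percentage points higher from compound 3 to compound 4 (within the scatter), and methoxy in place of amino on an aromatic carbon gives a number 4 percentage points higher from compound 1 to compound 4 (within the scatter). Across compounds 1, 3 and 4, this position has now taken three different aromatic groups without any step leaving the scatter. Nothing available explains this result.

Compound 2, at -26%, differs from these compounds in more than one place, so it cannot be tied to any single group. As far as these compounds go, whether a carboxylic acid or a dimethylamino group on that phenyl ring would leave the scatter stays open.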